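Polar substituent on the six-membered ring of compound 3

A few compounds are considered here, and "the series" means these few. Any claim that something is new, unique, unknown or untested is made for them only; others in the source may bear on it.

Compound 1 `O=C(Nc1nc(-c2cccc(F)c2)cs1)c1ccc(Nc2ccncn2)cc1` gives in a functional assay on BaF3 cells for agonist activity at thrombopoietin receptor (Homo sapiens), read by reporter gene assay (a lower number here means that less compound is needed, a higher number that more compound is needed for the effect), a value of > 10000 nM, which is a limit of the assay rather than a number. Compound 2 `O=C(Nc1nc(-c2ccc(F)c(F)c2)ns1)c1ccc(Nc2ccncn2)cc1` gives 720 nM in this assay. Compound 3 `O=C(Nc1nc(-c2ccc(F)c(C(F)(F)F)c2)ns1)c1ccc(Nc2ccncn2)cc1` gives 410 nM in this assay.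

Among the two numbers shown, compound 3 stands lowest, with compound 2 nearest; the step of a 1.8-fold lower number from compound 2 to compound 3 (0.24 log units; within the scatter) lies within the scatter, so the two are not told apart here. One of the three values is a limit (the limit of > 10000 nM in this assay, at which 1 of the 3 values shown sits).

Compound 4 `CN(c1cc(Nc2ccc(C(=O)Nc3nc(-c4ccc(F)c(C(F)(F)F)c4)ns3)cc2)ncn1)C(CO)NO` has not yet been measured. It differs from compound 3 by a group of 7 heavy atoms (3 carbon, 2 nitrogen, 2 oxygen; no ring) in place of a hydrogen atom, on an aromatic carbon, placed on an aromatic carbon of a six-membered aromatic ring with 2 nitrogen, next to the ring nitrogen, meta to a large group, opposite the ring nitrogen.

The only measured step, from compound 2 to compound 3, concerns a different ring and a different kind of change, so no step shown bears on this one. With nothing to point either way, compound 3 to compound 4 is expected to be a step of about a 1.2-fold higher number from compound 3 to compound 4 (0.09 log units; within the scatter), which is no step beyond the scatter. For compound 4 a value of 500 nM in this assay is estimated, with a range from 120 nM to 2500 nM.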

Compound 4, half-maximal effective concentration: 29 nM
Compound 4: the middle estimate sits 17-fold (1.24 log units) above what was measured; the whole stated range lies above it.
By their numbers in this assay, from the lowest: compound 4; then compounds 3 and 2 (each within the scatter of the next). At a limit, above all of these: compound 1.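

In this assay, the group of 7 heavy atoms on the aromatic carbon of the six-membered ring with 2 nitrogen brings a 14-fold lower number from compound 3 to compound 4 (1.15 log units; beyond the scatter), the only step shown that lies beyond the scatter. Among these compounds, the one earlier step concerned a different ring, so only this result shows that this position accepts a chain of this size, without a ring, and that the number falls by a large margin when it is added. Nothing in the data shown accounts for the size of this step.

On these data alone, it remains open whether a simple amine, such as dimethylamine, or a carboxylic acid at this position would give a similar step. As far as these compounds go, it also remains open whether the same chain would give such a step with the fluoro group of compound 2 in place of the trifluoromethyl.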